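Swapping Fluoro for Methoxy on the Pendant Ring

This account rests on a few compounds, and the source may have more. Where it says the series, first, only, none or still open, it means among the compounds named here.

Compound 1, `COc1ccc(S(=O)(=O)c2cnc3c(F)cccc3c2-c2cccc(F)c2)cc1`, was tested in an ADME assay on microsomes from liver (Homo sapiens) for metabolic stability, tested at 2.5 uM (a higher number here means faster removal of the compound, a lower number slower removal), where compound 1 gives 3.03 mL/min. For the measured compounds named here, that is the higher of the two numbers measured so far. Going by the values given here, the only comparison is compound 2, `O=S(=O)(c1cccc(F)c1)c1cnc2c(F)cccc2c1-c1cccc(F)c1`, which in this assay gives 1.14 mL/min; the step of a 2.7-fold lower number from compound 1 to compound 2 (0.42 log units; beyond the scatter) came from putting 3-fluorophenyl in place of 4-methoxyphenyl on the sulfonyl sulfur.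

Compound 3, `COc1ccc(S(=O)(=O)c2cnc3c(F)cccc3c2-c2cccc(OC)c2)cc1`, has not yet been measured. It differs from compound 1 at the other aromatic ring: methoxy in place of fluoro on an aromatic carbon, so the 3-fluorophenyl becomes 3-methoxyphenyl while the sulfonyl side is unchanged.

Among the compounds with values here, no measured step touches this ring, so the one step on record bears only indirectly. It does show that, on the sulfonyl side, the compound carrying methoxy rather than fluoro had the higher number, since compound 1 gives 3.03 mL/min against compound 2. Carrying that hint across, a modest rise is expected, a 1.5-fold higher number from compound 1 to compound 3 (0.17 log units; within the scatter), though a result within the scatter would not surprise. The estimate for compound 3 in this assay is 4.5 mL/min, with a range from 2.5 mL/min to 8 mL/min.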

Compound 3, intrinsic clearance in a liver preparation (reported as CLH), per the amount of preparation that the assay uses: 2.87 mL/min
The estimate for compound 3 lay 1.6-fold (0.20 log units) above the measured number, within the range that was stated.
By their numbers in this assay, from the lowest: compound 2; then compounds 3 and 1 (each within the scatter of the next).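

In this assay, exchanging fluoro for methoxy on this aromatic ring gives a 1.1-fold lower number from compound 1 to compound 3 (0.02 log units; within the scatter), so the 3-fluorophenyl and 3-methoxyphenyl forms cannot be told apart here, even though methoxy has 2 heavy atoms against 1 for fluoro and carries 1 hydrogen-bond acceptor. For the compounds shown here, at this place, meta to a large group, the change therefore leaves the number within the scatter, while the only step beyond the scatter so far remains a 2.7-fold lower number from compound 1 to compound 2 (0.42 log units; beyond the scatter), made on the sulfonyl side. No measurement shown gives a reason for this result.

The compounds shown hold only fluoro and methoxy at this place, so they leave open how the number would respond to an amine, a carboxylic acid or a longer chain such as butoxy there. They also leave open whether the same exchange of fluoro for methoxy would again stay within the scatter with 3-fluorophenyl on the sulfonyl sulfur, as in compound 2, rather than 4-methoxyphenyl.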